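Amide substituent series: dicarboxypropyl variant of compound 3

This account rests on a few compounds, and the source may have more. Where it says the series, first, only, none or still open, it means among the compounds named here.

Measured so far:
- compound 1, `CCn1c(C(=O)NCC(=O)OC)ccc1C(CC)(CC)c1ccc(OCS(=O)(=O)c2ccccc2)c(C)c1`: 20000 nM
- compound 2, `CCn1c(C(=O)NC2(CO)CC2)ccc1C(CC)(CC)c1ccc(OCS(=O)(=O)c2ccccc2)c(C)c1`: 45400 nM
- compound 3, `CCn1c(C(=O)N[C@@H](CO)CCCO)ccc1C(CC)(CC)c1ccc(OCS(=O)(=O)c2ccccc2)c(C)c1`: 16400 nM

All three share one core and differ only in the group on the amide-type nitrogen, measured in a functional assay on BXPC-3 cells (Homo sapiens) for antiproliferative activity, read by MTT assay, with a stated time of 24 h; on this read-out higher numbers stand for weaker inhibition and lower numbers for stronger inhibition. Compound 3 gives the lowest number of the three in this assay, but the step that separates it from the nearest compound is a 1.2-fold lower number from compound 1 to compound 3 (0.09 log units; within the scatter), so compound 3 and compound 1 cannot be ordered. Against compound 2 the gap is a 2.8-fold lower number from compound 2 to compound 3 (0.44 log units; beyond the scatter), and compound 1 to compound 2 is a 2.3-fold higher number from compound 1 to compound 2 (0.36 log units; beyond the scatter).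

Compound 4, `CCn1c(C(=O)N[C@@H](CCC(=O)O)C(=O)O)ccc1C(CC)(CC)c1ccc(OCS(=O)(=O)c2ccccc2)c(C)c1`, is not yet measured. Relative to compound 3 the change is a group of 9 heavy atoms (5 carbon, 4 oxygen; no ring) in place of a group of 7 heavy atoms (5 carbon, 2 oxygen; no ring), on an amide-type nitrogen. The bearing steps are those at the same position: one within the scatter, two modest and beyond it. Nothing in the series points to a large move from varying this group, so the step from compound 3 to compound 4 is expected to be small, in either direction, and most likely within the scatter; a modest shift in either sense would be consistent with compound 1 to compound 2 and compound 2 to compound 3. The expected step is a 1.1-fold higher number from compound 3 to compound 4 (0.04 log units; within the scatter). Compound 4 is estimated at 18000 nM in this assay, with a range of 8000 nM to 45000 nM.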

Compound 4, half-maximal inhibitory concentration: > 50000 nM
Compound 4: no number, only a limit; the forecaster's own chance of this, stated with the estimate: 15%; middle value at least 2.7-fold (0.44 log units) away from the limit.
By their numbers in this assay, from the lowest: compounds 3 and 1 (each within the scatter of the next); then compound 2. At a limit, above all of these: compound 4.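

Compound 4 alone stands at a limit rather than a number: the limit of > 50000 nM in this assay, at which 1 of the 4 values shown sits. In this assay, 1,3-dicarboxypropyl on the amide-type nitrogen gives the first shift in this series that is beyond the scatter against both compound 3 (an at least 3.0-fold higher number from compound 3 to compound 4 (0.48 log units; beyond the scatter)) and compound 1 (an at least 2.5-fold higher number from compound 1 to compound 4 (0.39 log units; beyond the scatter)), two compounds that cannot themselves be ordered. Against compound 2 the picture is less clear (an at least 1.1-fold higher number from compound 2 to compound 4 (0.04 log units; that floor lies within the scatter)): this floor does not separate 1-(hydroxymethyl)cyclopropyl from 1,3-dicarboxypropyl, so the two groups may lie close together or far apart.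

Still open, going by these compounds, is whether a single carboxylic acid on this nitrogen would read like the pair in 1,3-dicarboxypropyl, and how the dimethyl ester of the same chain or a chain ending in an amine would compare. The true size of all three new steps also remains open, as each has only a floor set by the limit for compound 4, and the series gives no cause for the shift.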